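Bromo in Place of Fluoro on the Shared Core

A few compounds are considered here, and "the series" means these few. Any claim that something is new, unique, unknown or untested is made for them only; others in the source may bear on it.

In a functional assay on A549 cells (Homo sapiens) for inhibition, read by sulforhodamine B assay, with a stated time of 48 h (a higher number here means a weaker inhibitor, a lower number a stronger inhibitor), compound 1 (`COC(=O)[C@H]1C[C@@H](c2coc3ccccc3c2=O)N(c2ccccc2)O1`) gives > 60000 nM as a limit of the assay and not a number. Compound 2 (`CCO[C@H]1C[C@@H](c2coc3ccc(F)cc3c2=O)N(c2ccccc2)O1`) gives 26400 nM and compound 3 (`O=c1c([C@@H]2C[C@H](c3ccccc3)ON2c2ccccc2)coc2ccc(F)cc12`) gives 51500 nM on the same read-out. Among the compounds with values here, the one measured step is a 2.0-fold higher number from compound 2 to compound 3 (0.29 log units; within the scatter) (phenyl in place of ethoxy on a saturated ring carbon), so compound 3 stands level with compound 2 within the scatter. Compound 4 (`O=c1c([C@@H]2C[C@H](c3ccccc3)ON2c2ccccc2)coc2ccc(Br)cc12`) differs from compound 3 by bromo in place of fluoro on an aromatic carbon. Within the data shown here, no single measured step changes that group, so none bears directly on it, and no step beyond the scatter is expected in this assay. The expected size is a 1.3-fold lower number from compound 3 to compound 4 (0.11 log units; within the scatter) at most by this reckoning. For compound 4 the estimated value is 40000 nM with an expected range (20000 nM to 65000 nM).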

Compound 4, half-maximal inhibitory concentration: 51000 nM
Estimate against measurement, compound 4: 1.3-fold (0.11 log units) below; low and high end bracket the measured number.
By their numbers in this assay, from the lowest: compounds 2, 4 and 3 (each within the scatter of the next). At a limit, above all of these: compound 1.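

In this assay, within the data shown here, the change of halogen gives a 1.0-fold lower number from compound 3 to compound 4 (0.00 log units; within the scatter), the first step at this aromatic carbon. With phenyl on the saturated ring carbon, the read-out therefore does not separate bromo from fluoro at this position. The series also contains a limit of the assay: the limit of > 60000 nM in this assay, at which 1 of the 4 values shown sits.

Going by these compounds, whether bromo and fluoro would also read alike with ethoxy on the saturated ring carbon remains open. So does what an amine or a carboxylic acid on this aromatic carbon would give.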